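A few compounds are considered here, and "the series" means these few. Any claim that something is new, unique, unknown or untested is made for them only; others in the source may bear on it.

Compound 1 `Cc1cc(C)cc(Cc2ccc3c(NCCCNCc4ccco4)ccnc3c2)c1` gives 23 10^-6 cm/s in an ADME assay for permeability, using PAMPA, with a stated time of 30 min, at pH 7.4; on this read-out higher numbers stand for higher permeability and lower numbers for lower permeability. Compound 2 `c1coc(CNCCCNc2ccnc3cc(CC4CCCCC4)ccc23)c1` gives 23 10^-6 cm/s in this assay, and compound 3 `COc1ccc(F)cc1CNCCCNc1ccnc2cc(Cc3cc(C)cc(C)c3)ccc12` gives 23 10^-6 cm/s. The step of no change at the digits printed from compound 1 to compound 2 (within the scatter) follows the change (cyclohexyl in place of 3,5-dimethylphenyl on a saturated chain carbon bound to an aromatic carbon). The step of no change at the digits printed from compound 1 to compound 3 (within the scatter) follows the change (5-fluoro-2-methoxyphenyl in place of furan-2-yl on a saturated chain carbon bound to an amine nitrogen). Compound 4 `COc1ccc(F)cc1CNCCCNc1ccnc2cc(CC3CCCCC3)ccc12` has not yet been measured in this assay; it differs from compound 3 by cyclohexyl in place of 3,5-dimethylphenyl on a saturated chain carbon bound to an aromatic carbon, the same change made from compound 1 to compound 2, while the cores of compound 3 and compound 1 differ by 5-fluoro-2-methoxyphenyl in place of furan-2-yl on a saturated chain carbon bound to an amine nitrogen. The step from compound 3 to compound 4 is expected to be no change at the digits printed from compound 3 to compound 4 (within the scatter), beside no change at the digits printed from compound 1 to compound 2 (within the scatter), because the step of no change at the digits printed from compound 1 to compound 2 (within the scatter) showed the same change leaving the read-out level. Compound 4 is therefore estimated at 23 10^-6 cm/s in this assay, between 14 10^-6 cm/s and 36 10^-6 cm/s.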

Compound 4, apparent permeability: 23 10^-6 cm/s
The estimate for compound 4 equals the measured number at the digits printed, within the range that was stated.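

In this assay, cyclohexyl in place of 3,5-dimethylphenyl gives no change at the digits printed from compound 3 to compound 4 (within the scatter), and the change carries from one core to the other with the same outcome: the same change on two cores in this assay, no change at the digits printed (within the scatter) from compound 1 to compound 2 and no change at the digits printed (within the scatter) from compound 3 to compound 4, 1.0-fold (0.00 log units) apart, within the scatter of two such steps

5-Fluoro-2-methoxyphenyl in place of furan-2-yl gives no change at the digits printed from compound 2 to compound 4 (within the scatter), and this change also carries with the same outcome: the same change on two cores in this assay, no change at the digits printed (within the scatter) from compound 1 to compound 3 and no change at the digits printed (within the scatter) from compound 2 to compound 4, 1.0-fold (0.00 log units) apart, within the scatter of two such steps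

This shows that both changes leave the read-out level on the cores of these four compounds, but it does not show that they would do so on any other core, or that a change that moved the read-out would carry in the same way.

The compounds shown leave open what a carboxylic acid or an amine would do in place of cyclohexyl. They also leave open what a longer chain joining the two amine nitrogens would do.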